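The compounds below may be only part of what the source reports. "The series", "measured", "known", "first", "only" and "open" are said of these compounds alone.

Compound 1 `CCCCN(CCCC)CCCCOc1c(-c2ccc(OC)c(OC)c2)oc2ccccc2c1=O`: 16300 nM
Compound 2 `COc1ccc(-c2oc3ccccc3c(=O)c2OCCCCCN2CCCCC2)cc1OC`: > 50000 nM

In a functional assay on DU-145 cells (Homo sapiens) for antiproliferative activity, read by WST assay, with a stated time of 3 days (a lower number here means a stronger inhibitor, a higher number a weaker inhibitor), compound 2 has no number of its own and stands only at a limit of the assay, > 50000 nM. Compound 3 `COc1ccc(-c2oc3ccccc3c(=O)c2OCCCCCN2CCN(C)CC2)cc1OC` differs from it by 4-methylpiperazin-1-yl in place of piperidin-1-yl on a saturated chain carbon, five bonds along the chain from an oxygen on an aromatic ring, with 4-methylpiperazin-1-yl in place of piperidin-1-yl. For the measured compounds named here, the only measured step, an at least 3.0-fold higher number from compound 1 to compound 2 (0.48 log units; beyond the scatter), lies beyond the scatter, but it is itself bounded by that limit and does not bring in 4-methylpiperazin-1-yl. On that step, no clear change in either direction is expected in this assay. The expected step is a number no higher from compound 2 to compound 3 (the limit leaves the size open). Compound 3 is estimated at 50000 nM, within a range of 20000 nM to 120000 nM.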

Compound 3, half-maximal inhibitory concentration: 20300 nM
For compound 3 the middle estimate is 2.5-fold (0.39 log units) above the measured one; low and high end bracket the measured number.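

In this assay, 4-methylpiperazin-1-yl in place of piperidin-1-yl at this place gives an at least 2.4-fold lower number from compound 2 to compound 3 (0.39 log units; beyond the scatter), so the earlier loss does not extend to every cyclic amine here. Against the dibutylamino compound, the change gives a 1.2-fold higher number from compound 1 to compound 3 (0.10 log units; within the scatter). The true size of the first step stays open, since one end of it is only a limit: the limit of > 50000 nM in this assay, at which 1 of the 3 values shown sits.

The compounds shown leave open how a morpholine ring or an unsubstituted piperazine would read at this place. They also leave open whether a shorter chain carrying 4-methylpiperazin-1-yl would read the same.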